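A lipophilic swap on the shared core of two sulfonamides

A few compounds are considered here, and "the series" means these few. Any claim that something is new, unique, unknown or untested is made for them only; others in the source may bear on it.

Compound 1 `CC(C)CCSc1cc(C(F)(F)F)ccc1CNC(=O)C(C)c1ccc(NS(C)(=O)=O)c(F)c1` gives 1.4 nM in an assay on CHO cells for antagonist activity at transient receptor potential cation channel subfamily V member 1 (Homo sapiens), read by FLIPR; on this read-out lower numbers stand for stronger inhibition and higher numbers for weaker inhibition. Compound 2 `CC(C(=O)NCc1ccc(C(F)(F)F)cc1SC1CCCC1)c1ccc(NS(C)(=O)=O)c(F)c1` gives 0.3 nM, which is a 4.7-fold lower number from compound 1 to compound 2 (0.67 log units; beyond the scatter). Among the two numbers so far, compound 2 stands lowest, its nearest neighbour being compound 1. Compound 3 `CC(C(=O)NCc1ccc(C(F)(F)F)cc1-c1cccc(Cl)c1)c1ccc(NS(C)(=O)=O)c(F)c1` differs from compound 2 by 3-chlorophenyl in place of cyclopentylsulfanyl on an aromatic carbon. For the measured compounds named here, the only measured step that touches this position is the one from compound 1 to compound 2, and it exchanged one saturated group for another while keeping the sulfur; it was modest in size. Going by the values given here, no measured step removes the sulfur or brings in an aromatic ring, so the direction of the change is uncertain, and a step no larger than modest is expected in either direction. Compound 3 is expected to give 1 nM, between 0.25 nM and 4 nM. The estimated step is a 3.3-fold higher number from compound 2 to compound 3 (0.52 log units; beyond the scatter).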

Compound 3, inhibition constant: 1 nM
Compound 3: the middle estimate sits on the measured number at the digits printed, and the stated range covers the measured number.
By their numbers in this assay, from the lowest: compound 2; then compounds 3 and 1 (each within the scatter of the next).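

Compounds 1 and 2 showed this position only with saturated groups on sulfur, whereas compound 3 shows that an aromatic ring can stand there without the sulfur, with a number still in the same low range. In this assay, 3-chlorophenyl in place of cyclopentylsulfanyl gives a 3.3-fold higher number from compound 2 to compound 3 (0.52 log units; beyond the scatter), while 3-chlorophenyl in place of isopentylsulfanyl gives a 1.4-fold lower number from compound 1 to compound 3 (0.15 log units; within the scatter), so the aromatic ring and the isopentylsulfanyl chain cannot be told apart and only cyclopentylsulfanyl stands apart from both. Nothing available bears on why cyclopentylsulfanyl differs from the other two groups.

Going by these compounds, it remains open how a cyclopentyloxy group, or a cyclopentyl group bonded directly to the aromatic carbon, would compare with cyclopentylsulfanyl. Also open, on these data alone, is how a phenyl ring without its chlorine would compare with 3-chlorophenyl.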